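A few compounds are considered here, and "the series" means these few. Any claim that something is new, unique, unknown or untested is made for them only; others in the source may bear on it.

Two compounds built on the shared core of compound 1, `CC(O)(CSc1ccc(F)cc1)c1nc(-c2ccc(Cl)cc2)no1`, have been tested in a functional assay on DU-145 cells (Homo sapiens) for cytotoxicity, read by MTT assay; on this read-out higher numbers stand for weaker inhibition and lower numbers for stronger inhibition. In this assay compound 1 gives 36300 nM. Going by the values given here, compound 2, `CC(O)(CSc1ccc(Cl)cc1)c1nc(-c2ccc(Cl)cc2)no1`, gives 14500 nM in this assay, the lowest of the two numbers so far; its nearest neighbour is compound 1. Among the compounds with values here, the only measured step, a 2.5-fold lower number from compound 1 to compound 2 (0.40 log units; beyond the scatter), came from putting chloro in place of fluoro on an aromatic carbon.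

Compound 3, `CC(O)(CSc1ccc(Br)cc1)c1nc(-c2ccc(Cl)cc2)no1`, has not yet been measured. It differs from compound 2 by bromo in place of chloro on an aromatic carbon of the six-membered aromatic ring of carbon only, para to a large group, so that the (4-chlorophenyl)sulfanyl group becomes a (4-bromophenyl)sulfanyl group. The step from compound 1 to compound 2 is the only one that bears on this change, since it is a halogen exchange at the same aromatic carbon, and it was modest though beyond the scatter. A similarly modest lowering of the number, or none beyond the scatter, is expected for compound 3, as a 1.6-fold lower number from compound 2 to compound 3 (0.21 log units; within the scatter). Compound 3 is therefore estimated at 9000 nM in this assay, within a range from 3500 nM to 25000 nM.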

Compound 3, half-maximal inhibitory concentration: 6500 nM
The estimate for compound 3 lay 1.4-fold (0.14 log units) above the measured number; the measured number falls inside the stated range.
By their numbers in this assay, from the lowest: compound 3; then compound 2; then compound 1.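

At the aromatic carbon that carries the halogen, going from the (4-chlorophenyl)sulfanyl group to the (4-bromophenyl)sulfanyl group gives a 2.2-fold lower number from compound 2 to compound 3 (0.35 log units; beyond the scatter) in this assay, so a second halogen exchange at this place moves the number in the same direction as the first. Taken end to end, the exchange of fluoro for bromo gives a 5.6-fold lower number from compound 1 to compound 3 (0.75 log units; beyond the scatter), which places the three halogens at this one carbon in a single order: compound 3 has the lowest number, compound 2 the middle one and compound 1 the highest. Nothing measured here accounts for this order.

The three compounds cannot show whether the order carries on to iodo, or how groups other than halogens, such as methoxy, a nitrile or an amine, would compare at the same carbon. The 4-chlorophenyl group that all three compounds share also leaves open whether bromo in place of chloro there would shift the number in the same way.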